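Adding a tert-Butoxycarbonyl Group to an Inactive Compound

The source may hold more compounds than are shown below. What is called first, only, known or untested is meant among the compounds shown, and "the series" means these compounds.

The compounds are tested in a functional assay on PC-3 cells (Homo sapiens) for inhibition, read by MTT assay, with a stated time of 72 h; on this read-out higher numbers stand for weaker inhibition and lower numbers for stronger inhibition. Compound 1, with the structure `COc1ccc(Cn2cc(CSC(=S)N3CCNCC3)nn2)cc1`, gives in this assay > 128000 nM, which is a limit of the assay rather than a number. Compound 2, with the structure `S=C(SCc1cn(Cc2ccc(Cl)c(Cl)c2)nn1)N1CCNCC1`, has no result in this assay: "not determined" (no result reported). Of the two entries shown, compound 1 thus sits at the limit of > 128000 nM in this assay, at which 1 of the 2 values shown sits, and no number sets it apart from anything else.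

Compound 3, with the structure `COc1ccc(Cn2cc(CSC(=S)N3CCN(C(=O)OC(C)(C)C)CC3)nn2)cc1`, differs from compound 1 in one place: tert-butoxycarbonyl in place of hydrogen on an amine nitrogen in a ring. Among the compounds with values here, no step between two measured compounds exists here, so the effect of this change can only be expected, not read off. The expected at least 1.2-fold lower number from compound 1 to compound 3 (0.10 log units; that floor lies within the scatter) is small, not beyond the scatter, given that compound 1 already sits at the limit of > 128000 nM in this assay, at which 1 of the 2 values shown sits. For compound 3 the estimate in this assay is 100000 nM, within a range from 20000 nM to 400000 nM, with a real chance that only a limit is reported again.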

Compound 3, half-maximal inhibitory concentration: > 128000 nM
Compound 3 gave a limit, no number; the forecaster's own chance of this, stated with the estimate: 60%; middle value at least 1.2-fold (0.10 log units) away from the limit.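

Compound 1 and compound 3 each give only a limit of the assay, not a number, so no step can be read between them. The compounds shown leave open whether tert-butoxycarbonyl in place of hydrogen on an amine nitrogen in a ring changes the result in this assay at all.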